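The source may hold more compounds than are shown below. What is called first, only, known or untested is meant among the compounds shown, and "the series" means these compounds.

Of the compounds shown here, three of one series have been tested in an ADME assay on Huh-7 cells (Homo sapiens) for cytotoxicity; on this read-out lower numbers stand for higher toxicity in this test and higher numbers for lower toxicity in this test. Compound 1, with the structure `CN1CCN(CCNCc2cn(-c3ccc(F)cc3F)nc2C2CCCCC2)CC1`, gives > 20000 nM in this assay, which is a limit of the measurement rather than a number. Compound 2, `COc1ccc(-n2cc(CNCCN3CCN(C)CC3)c(-c3ccccc3C)n2)cc1`, likewise reaches only the limit, reported as > 20000 nM. Compound 3, `CN1CCN(CCNCc2cc(-c3ccccc3)nn2-c2ccc(F)cc2)CC1`, also sits at the limit, reported as > 20000 nM. Compound 1 therefore stands no differently from the other two: the limit of > 20000 nM in this assay, at which 3 of the 3 values shown sit. Within the data shown here, no step between two measured compounds can be read from these values. Compound 4, `CN1CCN(CCNCc2cn(-c3ccc(F)cc3F)nc2-c2ccc(C(F)(F)F)cc2)CC1`, differs from compound 1 by 4-(trifluoromethyl)phenyl in place of cyclohexyl on an aromatic carbon. Because every shown value is a limit (the limit of > 20000 nM in this assay, at which 3 of the 3 values shown sit), the step of a number no higher from compound 1 to compound 4 (the limit leaves the size open) is expected to stay within the scatter. Compound 4 is thus expected to give about 20000 nM, within 8000 nM to 50000 nM.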

Compound 4, half-maximal cytotoxic concentration: 20000 nM
For compound 4 middle estimate and measured number coincide at the digits printed; the range from low to high includes it.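

In this assay, placing 4-(trifluoromethyl)phenyl instead of cyclohexyl on this aromatic carbon gives a number no higher from compound 1 to compound 4 (the limit leaves the size open). Compound 4 gives 20000 nM, which is a measured number rather than a limit, so this position now has one read-out that is not capped. The size of the step still cannot be read, because most values shown are limits: the limit of > 20000 nM in this assay, at which 3 of the 4 values shown sit.

On these data alone, what a carboxylic acid on this aromatic carbon would give in this assay remains open. So does the effect of a smaller group there, such as a methyl group.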